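This account rests on a few compounds, and the source may have more. Where it says the series, first, only, none or still open, it means among the compounds named here.

Working notes on the series. Compound 1 (`CSC(=S)N1CCN(C(=S)SC(=S)N(C)C)CC1`), compound 2 (`CCCCSC(=S)N1CCN(C(=S)SC(=S)N(C)C)CC1`) and compound 3 (`CN(C)C(=S)SC(=S)N1CCN(C(=S)SCCCC#N)CC1`) have been read in an ADME assay on HeLa cells (Homo sapiens) for cytotoxicity, read by MTT assay, with a stated time of 24 h; on this read-out higher numbers stand for weaker inhibition and lower numbers for stronger inhibition. Compound 1 gives > 5000000 nM as a limit of the assay. Compound 2 gives > 5000000 nM as a limit of the assay. Compound 3 gives > 5000000 nM as a limit of the assay, so it has no number of its own. For the measured compounds named here, the series so far stands at one mark (the limit of > 5000000 nM in this assay, at which 3 of the 3 values shown sit).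

The next entry is compound 4 (`CN(C)C(=S)SC(=S)N1CCN(C(=S)Nc2ccccc2)CC1`), which carries anilino in place of (3-cyanopropyl)sulfanyl on a thiocarbonyl carbon. It thereby gains one six-membered aromatic ring of carbon only.

Going by the values given here, three measured steps bear on this change, all of them on the chain bound to sulfur: a step that the two limits leave unreadable from compound 1 to compound 2, a step that the two limits leave unreadable from compound 1 to compound 3 and a step that the two limits leave unreadable from compound 2 to compound 3. None of them has a readable size, and none places anilino on the thiocarbonyl carbon, so they offer only weak guidance. With all three chains at the same limit in this assay, no step beyond the scatter and no direction is expected, and the expected outcome is a number no higher from compound 3 to compound 4 (the limit leaves the size open) for now. Compound 4 is estimated at 5000000 nM (expected range 1000000 nM to 10000000 nM), most likely reported as a limit again.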

Compound 4, half-maximal inhibitory concentration: > 5000000 nM
Compound 4: a limit, no number (the forecaster's own chance of this, stated with the estimate: 75%); the middle value sits exactly at the limit.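

Compound 4 also gives only a limit in this assay, so its steps from compound 1, compound 2 and compound 3 cannot be read. The compounds shown leave open whether any group on the thiocarbonyl carbon gives a measurable value in this read-out, as the whole series stands at one mark: the limit of > 5000000 nM in this assay, at which 4 of the 4 values shown sit.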